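Methoxy in Place of Fluoro on a Shared Core

A few compounds are considered here, and "the series" means these few. Any claim that something is new, unique, unknown or untested is made for them only; others in the source may bear on it.

Compound 1, `C=CC1=C(C(=O)Nc2ccccc2OC)C(c2ccc(OC)cc2)OC1`, in a functional assay on SW480 cells (Homo sapiens) for cytotoxicity, read by MTT assay, with a stated time of 24 h (on this read-out lower numbers stand for stronger inhibition and higher numbers for weaker inhibition), gives > 100000 nM, which is a limit of the assay rather than a number.
Compound 2, `C=CC1=C(C(=O)NCCC)C(c2ccc(OC)c(OC)c2)OC1`, in this assay gives > 100000 nM, again a limit.
Compound 3, `C=CC1=C(C(=O)NCCC)C(c2ccc(F)cc2)OC1`, in this assay gives > 100000 nM, also a limit.

All three measured compounds therefore sit at one and the same point: the limit of > 100000 nM in this assay, at which 3 of the 3 values shown sit. Compound 3 stands exactly where the other two stand, so no order among the three can be read from these numbers, and none can be called stronger or weaker than another.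

Compound 4, `C=CC1=C(C(=O)NCCC)C(c2ccc(OC)cc2)OC1`, has not yet been measured. It differs from compound 3 in one place: methoxy in place of fluoro on an aromatic carbon. The methoxy sits on an aromatic carbon, para to a large group.

Two measured compounds already carry a methoxy on such a ring. Compound 1 gives > 100000 nM. Compound 2 gives > 100000 nM. With every shown value resting at the limit, the step that the limit leaves unreadable from compound 3 to compound 4 is expected to be none beyond the scatter. Compound 4 is therefore estimated at 150000 nM, within a range from 50000 nM to 500000 nM, most likely reported only as a limit.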

Compound 4, half-maximal inhibitory concentration: > 100000 nM
Compound 4: only a limit was reported; the forecaster's own chance of this, stated with the estimate: 80%; the middle value is on the limit's open side.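

Compound 4 lands with compound 1, compound 2 and compound 3, so the steps from each of them to compound 4 cannot be read, and no order among the four can be given: the limit of > 100000 nM in this assay, at which 4 of the 4 values shown sit.

The compounds shown leave open whether any change to the shared core would give an actual number in this assay.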